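The compounds below may be only part of what the source reports. "The series", "measured", "known", "first", "only" and "open" are said of these compounds alone.

Compound 1 `N#CN/C(=N\CCCNc1ccccc1[N+](=O)[O-])NCCCCOc1cccc(CN2CCCCC2)c1` pairs a cyanoguanidine with a long chain that ends in a nitrophenylamino group. Among the compounds with values here, in a functional assay on cardiac atrium for antagonist activity at histamine H2 receptor (Cavia porcellus) (a higher number here means a more potent compound, by a factor of ten per unit of this negative logarithm, a lower number a less potent compound), compound 1 gives 7.85, the higher of the two values measured so far. Within the data shown here, the only comparison is compound 2 `O=C(NCCCOc1cccc(CN2CCCCC2)c1)NCCNC(=O)c1ccccc1`, a urea with a benzamide tail on a shorter linker, which in this assay gives 6.1; that gap is well beyond the usual scatter, so compound 1 stands clearly ahead, though the two structures differ in several places and no single step can be read from them.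

Compound 3 `Cc1ccc(S(=O)(=O)NCC/N=C(\NC#N)NCCCCOc2cccc(CN3CCCCC3)c2)cc1` keeps the cyanoguanidine and the whole shared core of compound 1 and changes only the far end of the chain: ((4-methylphenyl)sulfonyl)amino in place of ((2-nitrophenyl)amino)methyl on a saturated chain carbon, two bonds along the chain from a double-bonded nitrogen. The step from compound 1 to compound 3 has no measured parallel here, so only an expectation is possible. Since compound 1 reaches 7.85 with the core intact, compound 3 is expected to stay reasonably potent, with a modest loss estimated as a number 0.55 log units lower from compound 1 to compound 3 (beyond the scatter). The estimate for compound 3 is 7.3, with a plausible range from 6.5 to 8.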

Compound 3, negative logarithm of the antagonist equilibrium constant: 7.29
Compound 3: the middle estimate sits 0.01 log units above what was measured, within the range that was stated.
By their numbers in this assay, from the lowest: compound 2; then compound 3; then compound 1.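

In this assay, putting ((4-methylphenyl)sulfonyl)amino in place of ((2-nitrophenyl)amino)methyl on a saturated chain carbon, two bonds along the chain from a double-bonded nitrogen, gives a number 0.56 log units lower from compound 1 to compound 3 (beyond the scatter). This is a modest loss for a substantial change: the entering group brings sulfur, one nitrogen fewer and one hydrogen-bond acceptor fewer, although both groups have the same number of heavy atoms and each holds one six-membered aromatic ring of carbon only, and compound 3 still gives 7.29 in this assay. So this position accepts more than one aryl-bearing end group with only a limited drop in potency, but nothing measured here accounts for the size of that drop.

Because several features change in this single step, the compounds shown cannot separate the contribution of the sulfonyl link from that of the ring substituents. Also open, going by these compounds, is whether an aromatic ring is needed at this end at all, a question that a simple amine or a carboxylic acid in its place could address, while a longer chain carrying the ((4-methylphenyl)sulfonyl)amino group could show how much the distance from the core matters.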